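Moving a methoxy group from a sulfonamide to a urea

A few compounds are considered here, and "the series" means these few. Any claim that something is new, unique, unknown or untested is made for them only; others in the source may bear on it.

Measured compounds in a functional assay on HCT-116 cells (Homo sapiens) for antiproliferative activity, read by MTT assay, with a stated time of 72 h; on this read-out higher numbers stand for weaker inhibition and lower numbers for stronger inhibition:
compound 1 `CN(c1ccc2[nH]c(-c3n[nH]c4ccccc34)cc2n1)S(=O)(=O)c1ccccc1` gives 6740 nM
compound 2 `COc1ccc(S(=O)(=O)N(C)c2ccc3[nH]c(-c4n[nH]c5ccccc45)cc3n2)cc1` gives 22400 nM
compound 3 `CN(C(=O)Nc1ccccc1)c1ccc2[nH]c(-c3n[nH]c4ccccc34)cc2n1` gives 1.3 nM

All three compounds share one core, and they differ only in what is attached to a methylated nitrogen on that core. Compound 1 carries a phenylsulfonyl group there; compound 3 carries a phenylcarbamoyl group instead. That single swap is described as phenylcarbamoyl in place of phenylsulfonyl on a nitrogen on an aromatic ring, and it made the largest step in the set: a 5200-fold lower number from compound 1 to compound 3 (3.71 log units; beyond the scatter). Compound 3 therefore stands with the lowest number of the three measured compounds.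

Compound 2 differs from compound 1 by methoxy in place of hydrogen on an aromatic carbon. In this assay this addition gave a 3.3-fold higher number from compound 1 to compound 2 (0.52 log units; beyond the scatter), a modest step and the only measured case of this change.

The unmeasured compound 4 `COc1ccc(NC(=O)N(C)c2ccc3[nH]c(-c4n[nH]c5ccccc45)cc3n2)cc1` differs from compound 3 by methoxy in place of hydrogen on an aromatic carbon. The change itself and its place read the same as the change from compound 1 to compound 2, so it is the same change, made this time on the urea rather than on the sulfonamide.

Whether the step repeats on the far more potent urea is not known from these data. Taking the measured step from compound 1 to compound 2 as the only guide, compound 4 is expected to show a 3.1-fold higher number from compound 3 to compound 4 (0.49 log units; beyond the scatter), a modest weakening that would still leave it well below compound 1 and compound 2. On that basis the estimated value of compound 4 in this assay is 4 nM, with a likely range from 1 nM to 15 nM.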

Compound 4, half-maximal inhibitory concentration: 63 nM
Beside the measured number, compound 4's estimate is 16-fold (1.20 log units) below it; measured number above the stated range.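

In this assay, putting the methoxy group on the urea gave a 48-fold higher number from compound 3 to compound 4 (1.69 log units; beyond the scatter), and this step does not match the one seen on the sulfonamide: the same change on two cores in this assay, a 3.3-fold higher number (0.52 log units; beyond the scatter) from compound 1 to compound 2 and a 48-fold higher number (1.69 log units; beyond the scatter) from compound 3 to compound 4, 15-fold (1.16 log units) apart, beyond the scatter of two such steps. Both steps run in the same direction, so on these two pairs the methoxy group raised the number each time, but the size of the step did not carry over from one core to the other. Two pairs cannot explain why the sizes differ, nor can they say how the same change would behave on any further core in this series.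

As far as these compounds go, only hydrogen and methoxy appear at this place on the ring, so it remains open whether the large step on the urea belongs to methoxy in particular or would also appear with another group, such as fluorine, methyl or hydroxy. From the compounds shown here alone, it also remains open whether a methoxy group on a different carbon of the same ring would give a large step on the urea, a small one or none beyond the scatter.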